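The source may hold more compounds than are shown below. What is called first, only, known or untested is meant among the compounds shown, and "the series" means these compounds.

Measured so far in a functional assay on NCI-H322M cells (Homo sapiens) for inhibition, read by sulforhodamine B assay, with a stated time of 48 h; a lower number here means that less compound is tolerated, a higher number that more compound is tolerated:

compound 1 `COc1cc(-c2nn(-c3cccc(NC(=O)Nc4cc(C(F)(F)F)cc(C(F)(F)F)c4)c3)cc2-c2ccncc2)ccc1Cl`: 29900 nM
compound 2 `COc1cc(-c2nn(-c3cccc(NC(=O)Nc4ccc(Cl)c(Cl)c4)c3)cc2-c2ccncc2)ccc1Cl`: a limit of the assay, > 50000 nM
compound 3 `O=C(Nc1cccc(-n2cc(-c3ccncc3)c(-c3ccc(Cl)c(O)c3)n2)c1)Nc1ccc(Cl)c(Cl)c1`: a limit of the assay, > 32500 nM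

Compound 2 stands at a limit of this assay and gives no number, only > 50000 nM. Compound 3 likewise sits at a limit, > 32500 nM. Only compound 1 gives a number in this assay, 29900 nM. Two of the three values are therefore limits: the limit of > 50000 nM in this assay, at which 1 of the 3 values shown sits, and (the limit of > 32500 nM in this assay, at which 1 of the 3 values shown sits). Going by the values given here, the one step among the measured compounds, a step that the two limits leave unreadable from compound 2 to compound 3, cannot be read because both ends are limits.

Compound 4 `COc1cc(-c2nn(-c3cccc(NC(=O)c4ccc(Cl)c(C(F)(F)F)c4)c3)cc2-c2ccncc2)ccc1Cl` differs from compound 2 by 4-chloro-3-(trifluoromethyl)phenyl in place of (3,4-dichlorophenyl)amino on a carbonyl carbon. Among the compounds with values here, no measured step covers this exchange, and the only step that exists cannot be read, so the expectation for compound 4 rests on where compound 2 stands and on the numbered value of compound 1 in this assay. Compound 4 is estimated to give about 40000 nM, between 12000 nM and 100000 nM. The step from compound 2 expected from this estimate, an at least 1.2-fold lower number from compound 2 to compound 4 (0.09 log units; that floor lies within the scatter), is not one beyond the scatter, and a further limit rather than a number is a likely outcome.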

Compound 4, concentration lethal to 50% of the cells: > 32500 nM
Compound 4 ended at the assay's limit (the forecaster's own chance of this, stated with the estimate: 50%); the middle value is on the limit's open side.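

In this assay compound 4 stands at a limit, > 32500 nM, and gives no number. Compound 2 is a limit as well, and the step between compound 2 and compound 4 cannot be read. The compounds shown leave open whether 4-chloro-3-(trifluoromethyl)phenyl in place of (3,4-dichlorophenyl)amino on a carbonyl carbon shifts the read-out in either direction.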